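Chloro to methoxy on the pendant phenyl of compound 2

This account rests on a few compounds, and the source may have more. Where it says the series, first, only, none or still open, it means among the compounds named here.

Compound 1: `Clc1ccc(-c2nn(-c3ccccc3)cc2-c2nc3cc(Cl)ccc3[nH]2)cc1`, 1170 nM
Compound 2: `O=C(OCc1ccccc1)c1ccc2[nH]c(-c3cn(-c4ccccc4)nc3-c3ccc(Cl)cc3)nc2c1`, 13900 nM

In a functional assay on MCF7 cells (Homo sapiens) for antiproliferative activity, read by MTT assay, with a stated time of 48 h (a higher number here means a weaker inhibitor, a lower number a stronger inhibitor), compound 2 gives 13900 nM, the highest of the two numbers; the nearest is compound 1, reached by a 12-fold higher number from compound 1 to compound 2 (1.07 log units; beyond the scatter), a change at another place. Compound 3 is `COc1ccc(-c2nn(-c3ccccc3)cc2-c2nc3cc(C(=O)OCc4ccccc4)ccc3[nH]2)cc1`; it differs from compound 2 by methoxy in place of chloro on an aromatic carbon, the 4-chlorophenyl becoming 4-methoxyphenyl. Among the measured compounds shown here, no measured step touches this group, so no size or direction is indicated. The expected step is a 1.0-fold higher number from compound 2 to compound 3 (0.00 log units; within the scatter). Compound 3 is therefore estimated at 14000 nM, between 5000 nM and 40000 nM.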

Compound 3, half-maximal inhibitory concentration: 7460 nM
For compound 3 the middle estimate is 1.9-fold (0.27 log units) above the measured one, within the range that was stated.
By their numbers in this assay, from the lowest: compound 1; then compounds 3 and 2 (each within the scatter of the next).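

In this assay, 4-methoxyphenyl in place of 4-chlorophenyl gives a 1.9-fold lower number from compound 2 to compound 3 (0.27 log units; within the scatter), so with the benzyloxycarbonyl group present, methoxy and chloro cannot be told apart at this position. Among the compounds shown here, this is the first reading at this position, as the earlier step concerned only the chloro to benzyloxycarbonyl change at another place. No measurement on hand explains the result.

From the compounds shown here alone, whether the same equivalence holds with the chloro substituent of compound 1 in place of benzyloxycarbonyl remains open. Also open, going by these compounds, is how an amine or a carboxylic acid would read at this position.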